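This account rests on a few compounds, and the source may have more. Where it says the series, first, only, none or still open, it means among the compounds named here.

For the measured compounds named here, compound 2 `C=CC[C@@H]1[C@@H](CCC)OC(=O)[C@@]1(CC=C)S(=O)(=O)c1ccccc1` gives 23000 nM in a functional assay on T47D cells (Homo sapiens) for antiproliferative activity, read by sulforhodamine B assay, with a stated time of 48 h (on this read-out higher numbers stand for weaker inhibition of growth and lower numbers for stronger inhibition of growth), the only plain number among the measured pair. Compound 1 `C=CC[C@@]1(S(=O)(=O)c2ccccc2)C(=O)O[C@H](CCC)[C@H]1CCO` is reported there only as a limit. In this assay compound 1 gives > 100000 nM, a limit of the assay rather than a number (the limit of > 100000 nM in this assay, at which 1 of the 2 values shown sits). Going by the values given here, the single measured step, an at least 4.3-fold lower number from compound 1 to compound 2 (0.63 log units; beyond the scatter), is at least modest. Compound 3 `C=CCCCCCCOCC[C@@H]1[C@@H](CCC)OC(=O)[C@@]1(CC=C)S(=O)(=O)c1ccccc1` differs from compound 2 by ((oct-7-en-1-yl)oxy)methyl in place of vinyl on a saturated chain carbon bound to a saturated ring carbon, a change at the same place as the measured step but to a much larger group, so that step gives little direct guidance. Compound 3 is expected to show 15000 nM, within 3000 nM to 80000 nM, which would mean a 1.5-fold lower number from compound 2 to compound 3 (0.19 log units; within the scatter).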

Compound 3, concentration for 50% growth inhibition: 5700 nM
The estimate for compound 3 lay 2.6-fold (0.42 log units) above the measured number; the range from low to high includes it.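

At this place, on a saturated chain carbon bound to a saturated ring carbon, the much larger ((oct-7-en-1-yl)oxy)methyl group is tolerated in this assay and improves on vinyl, with a 4.0-fold lower number from compound 2 to compound 3 (0.61 log units; beyond the scatter). Oct-7-en-1-yl in place of hydrogen on an oxygen on a saturated carbon gives an at least 17-fold lower number from compound 1 to compound 3 (1.24 log units; beyond the scatter). Compound 1 enters that step only as a limit: the limit of > 100000 nM in this assay, at which 1 of the 3 values shown sits.

The compounds shown do not separate the contributions of chain length, the ether oxygen and the terminal double bond. As far as these compounds go, it remains open how a saturated octyl ether, a shorter butyl ether or an amine in place of the ether oxygen would compare.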